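Ester variation on the cyclohexyl anilide core

The source may report more compounds than this note shows. Statements on the series, on what has been measured and on what is new or still open speak of the compounds shown alone.

Measured so far:
- compound 1, `Cc1ccccc1C(=O)OC1(C(=O)Nc2ccc([N+](=O)[O-])cc2)CCCCC1`: 352 nM
- compound 2, `O=C(OC1(C(=O)Nc2ccc([N+](=O)[O-])cc2)CCCCC1)c1ccc(Br)cc1`: 523 nM

In an ADME assay on WI-38 cells (Homo sapiens) for inhibition, read by MTT assay, with a stated time of 72 h (a higher number here means a weaker inhibitor, a lower number a stronger inhibitor), compound 1 gives 352 nM and compound 2 gives 523 nM. Going by the values given here, the only step on record, a 1.5-fold higher number from compound 1 to compound 2 (0.17 log units; within the scatter), changes nothing beyond the scatter. Among the compounds with values here, compound 2 thus stands at the higher of two numbers, with compound 1 its only neighbour, the two being indistinguishable within the scatter.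

Compound 3, `O=C(/C=C/c1ccccc1)OC1(C(=O)Nc2ccc([N+](=O)[O-])cc2)CCCCC1`, is the next point. Its change from compound 2 is 2-phenylethenyl in place of 4-bromophenyl on a carbonyl carbon. Within the data shown here, no measured step touches this change; the one step available, a 1.5-fold higher number from compound 1 to compound 2 (0.17 log units; within the scatter), shows only that swapping one substituted phenyl for another on the ester carbonyl leaves this assay essentially unmoved. Among the measured compounds shown here, on that basis the expectation for compound 3 is a step of about a 1.0-fold lower number from compound 2 to compound 3 (0.02 log units; within the scatter), that is none beyond the scatter, though with wide uncertainty since the entering group is the first that is not an aromatic ring directly on the carbonyl. Compound 3 is therefore estimated at 500 nM, within 200 nM to 1300 nM.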

Compound 3, half-maximal inhibitory concentration: 41 nM
Compound 3: the middle estimate sits 12-fold (1.09 log units) above what was measured; measured number outside the range, below it.
By their numbers in this assay, from the lowest: compound 3; then compounds 1 and 2 (each within the scatter of the next).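

The group on the ester carbonyl carbon is not a silent place in this assay: the earlier pair hinted at little change, yet 2-phenylethenyl gives a 13-fold lower number from compound 2 to compound 3 (1.11 log units; beyond the scatter) and an 8.6-fold lower number from compound 1 to compound 3 (0.93 log units; beyond the scatter). Exchanging 4-bromophenyl and 2-methylphenyl therefore says little about the range of this place, and a different kind of group can move the number well beyond the scatter. Between compound 2 and compound 3, the aromatic ring count, hydrogen-bond donors, hydrogen-bond acceptors and net charge stay the same, while bromine leaves and a double bond outside aromatic rings enters, but nothing available explains the step.

Three compounds cannot tell whether the double bond itself matters, and 2-phenylethyl, the saturated counterpart, or a simple alkyl chain at this place would address that question. Going by these compounds, it also remains open whether the step holds when an amine or a carboxylic acid is carried on the phenyl ring of the 2-phenylethenyl group, or when the rest of the shared core is changed.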